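Pushing the branched chain one methyl further in compound 4

This account rests on a few compounds, and the source may have more. Where it says the series, first, only, none or still open, it means among the compounds named here.

Compound 3 `CCCn1nc(C(C)C)c(C(=O)O)c1Cc1ccc(-c2ccccc2-c2nn[nH]n2)cc1` stands at the top of the three numbers in hand. In a functional assay on the whole organism for inhibition, with Rattus norvegicus as the target, at a dose of 0.3 mg/kg (on this read-out higher numbers stand for more inhibition at the one dose given (going by the name of the read-out) and lower numbers for less inhibition), compound 3 gives 80.4%, while compound 1 `CCCCn1nc(CC)c(C(=O)O)c1Cc1ccc(-c2ccccc2-c2nn[nH]n2)cc1` gives 65.2% and compound 2 `CCCCn1nc(C(C)C)c(C(=O)O)c1Cc1ccc(-c2ccccc2-c2nn[nH]n2)cc1` gives 42.7%. Both gaps below compound 3 are beyond the scatter.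

Compound 4 `CCCn1nc(C(C)(C)C)c(C(=O)O)c1Cc1ccc(-c2ccccc2-c2nn[nH]n2)cc1` differs from compound 3 by methyl in place of hydrogen on a saturated chain carbon bound to an aromatic carbon and two saturated chain carbons, the same difference that, cut one bond further out, reads isopropyl to tert-butyl.

Within the data shown here, two measured steps bear on this. The closest in kind is a number 22.5 percentage points lower from compound 1 to compound 2 (beyond the scatter), where a methyl also entered on a saturated chain carbon bound to an aromatic carbon, a step that lowered the read-out. The other, a number 37.7 percentage points higher from compound 2 to compound 3 (beyond the scatter), concerns the chain on the aromatic nitrogen instead and so sets the level of compound 3 rather than the direction of the new change.

Among the measured compounds shown here, the one comparable step was a modest fall, so a fall of similar size is expected for compound 4, as a number 22.4 percentage points lower from compound 3 to compound 4 (beyond the scatter). Compound 4 is therefore estimated at 58%, with a range from 35% to 78%.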

Compound 4, a percentage reported as inhibition, in the whole organism at one dose (the size of the read-out at that dose, not a potency): 61.2%
The estimate for compound 4 lay 3.2 percentage points below the measured number; measured number inside the range.
By their numbers in this assay, from the lowest: compound 2; then compounds 4 and 1 (each within the scatter of the next); then compound 3.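

In this assay, the result of a number 19.2 percentage points lower from compound 3 to compound 4 (beyond the scatter) shows that a methyl entering on the saturated chain carbon bound to an aromatic carbon lowers the read-out on a second core, here on a carbon that already carries two saturated chain carbons. Before compound 4, this change rested on a single step, which might have been peculiar to one core; it now recurs in the same direction and at a similar size: the same change on two cores in this assay, a number 22.5 percentage points lower (beyond the scatter) from compound 1 to compound 2 and a number 19.2 percentage points lower (beyond the scatter) from compound 3 to compound 4, 3.3 percentage points apart, within the scatter of two such steps Across these two steps the size of the fall stays within the scatter, whether the methyl enters on a carbon bound to one saturated chain carbon or to two.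

The compounds shown leave open whether the fall follows the branching at this carbon or simply the added carbon, a question that a straight propyl chain or a cyclopropyl ring in this place could help to separate. They also leave open how far these falls would hold at other doses, as every number here comes from a single dose and none of them is a potency.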